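A few compounds are considered here, and "the series" means these few. Any claim that something is new, unique, unknown or untested is made for them only; others in the source may bear on it.

Working notes on the hydroxamic acid series.

Compound 1 `O=C(CCCCC[C@H](NC(=O)OCc1ccccc1)C(=O)NCc1ccccc1)NO` is the reference point. In a functional assay on NFF cells (Homo sapiens) for antiproliferative activity (a lower number here means a stronger inhibitor, a higher number a weaker inhibitor), compound 1 gives 1520 nM. Compound 2 `O=C(CCCCC[C@H](NC(=O)c1cc2c(Br)cccc2[nH]1)C(=O)NCc1ccccc1)NO` carries 4-bromo-1H-indol-2-yl in place of benzyloxy on a carbonyl carbon; in this assay compound 2 gives 1940 nM. The step of a 1.3-fold higher number from compound 1 to compound 2 (0.11 log units; within the scatter) lies within the scatter, so the two numbers are read as equivalent, and compound 1 is simply the lower of the two without any claim to an order.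

Compound 3 `CN(C)c1ccc(NC(=O)[C@H](CCCCCC(=O)NO)NC(=O)OCc2ccccc2)cc1` differs from compound 1 at the other end of the core: 4-(dimethylamino)phenyl in place of benzyl on an amide-type nitrogen. Among the measured compounds shown here, no measured step touches this amide-type nitrogen; the only step available concerns the carbonyl carbon on the opposite side, and that one was within the scatter. There is therefore no basis in the data for a directional expectation, and the estimate for compound 3 rests on compound 1 alone, which gives 1520 nM in this assay.

For compound 3 the expected value in this assay is 1500 nM, with a range from 500 nM to 4500 nM. The expected step of a 1.0-fold lower number from compound 1 to compound 3 (0.01 log units; within the scatter) is no change beyond the scatter.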

Compound 3, half-maximal inhibitory concentration: 650 nM
Compound 3: middle estimate off by 2.3-fold (0.36 log units), on the high side; low and high end bracket the measured number.
By their numbers in this assay, from the lowest: compound 3; then compounds 1 and 2 (each within the scatter of the next).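

In this assay, the amide-type nitrogen proves to be a position that responds: a 2.3-fold lower number from compound 1 to compound 3 (0.37 log units; beyond the scatter), a modest step, but the first in the series beyond the scatter, whereas the change on the carbonyl carbon, a 1.3-fold higher number from compound 1 to compound 2 (0.11 log units; within the scatter), stayed within it. Replacing benzyl with 4-(dimethylamino)phenyl therefore favours the lower number in this one pair, with the entering group adding a nitrogen and a hydrogen-bond acceptor that benzyl lacks, although a single pair does not establish a trend for this position. No supporting data are available to explain the shift, so the step stands as an observation only.

The change from benzylamino to (4-(dimethylamino)phenyl)amino alters more than one feature at once, and whether the step follows the dimethylamino group or the replacement of benzyl by a phenyl ring remains unresolved; plain phenyl and 4-(dimethylamino)benzyl on the same nitrogen are the groups that could separate the two. Also open, going by these compounds, is whether the step holds when 4-bromo-1H-indol-2-yl replaces benzyloxy on the carbonyl carbon, and how a smaller group such as methyl on this nitrogen compares.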